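A few compounds are considered here, and "the series" means these few. Any claim that something is new, unique, unknown or untested is made for them only; others in the source may bear on it.

Working notes on the series. Compound 1 `CC(C)C(c1ccc(-c2ccc3cccc(F)c3c2)[nH]c1=O)N1CCCCC1=O` carries a 2-oxopiperidin-1-yl group on the chain carbon that joins the shared core; in an assay on CHO cells for displacement of a labelled ligand from prostaglandin E2 receptor EP3 subtype (Homo sapiens), read by radioligand binding (a lower number here means a stronger inhibitor, a higher number a weaker inhibitor), compound 1 gives 6.4 nM. Within the data shown here, the only other measured analogue, compound 2 `CCn1ncc2c(F)cc(-c3ccc(C(CC)(CC)c4nnc[nH]4)c(=O)[nH]3)cc21`, gives 17 nM in this assay, so compound 1 holds the lower of the two numbers, and the gap between them lies beyond the usual scatter. Compound 3 `Cc1c[nH]c(C(c2ccc(-c3ccc4cccc(F)c4c3)[nH]c2=O)C(C)C)n1` has not been measured. It differs from compound 1 in one place: 4-methyl-1H-imidazol-2-yl in place of 2-oxopiperidin-1-yl on a saturated chain carbon bound to an aromatic carbon and a saturated chain carbon. Among the measured compounds shown here, no measured pair in the set shows this exchange, so its effect is not known from the data. A modest move toward a weaker value is expected in this assay, with the step from compound 1 to compound 3 estimated at a 1.9-fold higher number from compound 1 to compound 3 (0.27 log units; within the scatter). Compound 3 is therefore expected to give about 12 nM, with a plausible range from 3 nM to 50 nM.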

Compound 3, inhibition constant: 12 nM
For compound 3 middle estimate and measured number coincide at the digits printed; low and high end bracket the measured number.
By their numbers in this assay, from the lowest: compounds 1, 3 and 2 (each within the scatter of the next, the first and the last beyond it).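

On the saturated chain carbon bound to an aromatic carbon and a saturated chain carbon, 4-methyl-1H-imidazol-2-yl can take the place of 2-oxopiperidin-1-yl in this assay with a step of a 1.9-fold higher number from compound 1 to compound 3 (0.27 log units; within the scatter), so this position accepts the exchange without a change beyond the scatter. The exchange replaces a six-membered non-aromatic ring without a hydrogen-bond donor by a five-membered aromatic ring with one, and in this single pair neither difference shows up as a step beyond the scatter. No measurement in hand accounts for this result.

On these data alone, whether the methyl on the imidazole matters, and how an unsubstituted 1H-imidazol-2-yl, an open-chain amide or a carboxylic acid on this chain carbon would read in this assay, remains open. Also open, as far as these compounds go, is whether the exchange reads the same on the core of compound 2.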